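A few compounds are considered here, and "the series" means these few. Any claim that something is new, unique, unknown or untested is made for them only; others in the source may bear on it.

Working notes on the series

Compound 1 `NC(=S)c1ccc(OC(=O)c2cccnc2)cc1` is read in an ADME assay on WI-38 cells (Homo sapiens) for cytotoxicity, read by MTT assay, with a stated time of 48 h; a higher number here means a weaker inhibitor, a lower number a stronger inhibitor. In this assay compound 1 gives only a limit, > 800000 nM. Compound 2 `O=C(Oc1ccc(-c2cc(=S)ss2)cc1)c1cccnc1` carries the change a group of 6 heavy atoms (3 carbon, 3 sulfur; one five-membered aromatic ring with 2 hetero atoms) in place of a group of 3 heavy atoms (1 carbon, 1 nitrogen, 1 sulfur; no ring), on an aromatic carbon on the same core, and in this assay compound 2 gives 734000 nM. The measured step is an at least 1.0-fold lower number from compound 1 to compound 2 (0.03 log units; that floor lies within the scatter), which rests on a limit on one side and so cannot be read as a real move; this is consistent with the limit of > 800000 nM in this assay, at which 2 of the 3 values shown sit.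

Compound 3 `CC(C)(Oc1ccc(Cl)cc1)C(=O)Oc1ccc(C(N)=S)cc1` has a different core from compound 1; the difference between the two cores is not broken down here. In this assay compound 3 gives only a limit, > 800000 nM. Compound 4 `CC(C)(Oc1ccc(Cl)cc1)C(=O)Oc1ccc(-c2cc(=S)ss2)cc1` is not yet measured in this assay. It carries the change (a group of 6 heavy atoms (3 carbon, 3 sulfur; one five-membered aromatic ring with 2 hetero atoms) in place of a group of 3 heavy atoms (1 carbon, 1 nitrogen, 1 sulfur; no ring), on an aromatic carbon), the same kind of change as that from compound 1 to compound 2, though the surroundings of the exchanged group are not described in the same words for the two cores.

Given that the only measured instance of this change, from compound 1 to compound 2, did not move the number beyond the scatter, and that compound 3 sits at the limit > 800000 nM, the expected step from compound 3 to compound 4 is an at least 1.0-fold lower number from compound 3 to compound 4 (0.02 log units; that floor lies within the scatter), again within the scatter and possibly reported only as a limit. Compound 4 is estimated at 750000 nM in this assay, expected within a range from 450000 nM to 900000 nM.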

Compound 4, half-maximal inhibitory concentration: 764000 nM
Compound 4: middle estimate off by 1.0-fold (0.01 log units), on the low side; the measured number falls inside the stated range.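

In this assay, putting the group of 6 heavy atoms, with its five-membered aromatic ring, in place of the group of 3 heavy atoms gives an at least 1.0-fold lower number from compound 3 to compound 4 (0.01 log units; that floor lies within the scatter), a step that rests on a limit on one side and so cannot be read as a real move. Set beside the earlier step, the change carried to a second core gives no move beyond the scatter on either core, but this does not establish that the two steps are equal: the same change on two cores in this assay, an at least 1.0-fold lower number (0.03 log units; that floor lies within the scatter) from compound 1 to compound 2 and an at least 1.0-fold lower number (0.01 log units; that floor lies within the scatter) from compound 3 to compound 4; the limit leaves it open whether they differ With the starting compound on each core reported only as a limit, the series shows neither the true size of the change nor whether that size carries from one core to the other: the limit of > 800000 nM in this assay, at which 2 of the 4 values shown sit.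

The compounds shown leave open whether another group at this place, such as an amine or a carboxylic acid, would give a number clear of the limit in this assay. They also leave open whether the same change would behave alike on a core carrying a longer chain, since the comparison rests on two cores only.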